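This account rests on a few compounds, and the source may have more. Where it says the series, first, only, none or still open, it means among the compounds named here.

Three compounds have been measured in an ADME assay on HEp-2 cells (Homo sapiens) for cytotoxicity, read by trypan blue exclusion, with a stated time of 24 h (on this read-out higher numbers stand for lower toxicity in this test and lower numbers for higher toxicity in this test), so far:
compound 1 `CC(C)=N/N=C1\SCC(=O)N1CN1C(=O)c2ccccc2C1=O` gives 22 ug/mL
compound 2 `O=C1CS/C(=N\N=C2CCCC2)N1Cc1ccc([N+](=O)[O-])cc1` gives 28 ug/mL
compound 3 `C/C(CC(C)C)=N\N=C1/SCC(=O)N1Cc1cccc2ccccc12` gives 95 ug/mL

Compound 1 sits at the low end of these numbers, within the scatter of compound 2, while compound 3 lies beyond the scatter above it. Compound 4 `C/C(CC(C)C)=N\N=C1/SCC(=O)N1CN1C(=O)c2ccccc2C1=O` is compound 1 with one change, (isopropyl in place of hydrogen on a saturated chain carbon bound to a carbon with a double bond to nitrogen), namely isopropyl in place of hydrogen on a saturated chain carbon bound to a carbon with a double bond to nitrogen. For the measured compounds named here, no measured pair shows this change alone. Compound 3 (95 ug/mL) carries the same chain but differs elsewhere, so only a modest upward step is expected, near the edge of the scatter. The expected step is a 2.0-fold higher number from compound 1 to compound 4 (0.31 log units; beyond the scatter) in this assay terms. The estimated value for compound 4 is 45 ug/mL (range 20 ug/mL to 100 ug/mL).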

Compound 4, half-maximal cytotoxic concentration: 99 ug/mL
Compound 4: the middle estimate sits 2.2-fold (0.34 log units) below what was measured, and the stated range covers the measured number.
By their numbers in this assay, from the lowest: compounds 1 and 2 (each within the scatter of the next); then compounds 3 and 4 (each within the scatter of the next).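

In this assay, for the compounds shown here, the one-place pair gives a 4.5-fold higher number from compound 1 to compound 4 (0.65 log units; beyond the scatter) and so supplies the first direct reading of this change: on the core of compound 1, isopropyl in place of hydrogen at this position goes with lower toxicity in this test. The position therefore tolerates this added carbon group without a rise in toxicity in this test. Nothing measured here bears on why the number moves.

Going by these compounds, it remains open whether a smaller methyl, a longer chain or an amine at this place would move the number likewise. On these data alone, whether the step holds with other groups elsewhere on the core also remains open.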